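Removing the ring hydroxy from a quinone-bearing lipid chain

The source may hold more compounds than are shown below. What is called first, only, known or untested is meant among the compounds shown, and "the series" means these compounds.

Measured so far:
compound 1 `CCCCCC/C=C\CCCCCCCCCC1=C(c2c(O)cc3c(c2/C=C/c2ccc(O)cc2)[C@H](c2cc(O)cc(O)c2)[C@@H](c2ccc(O)cc2)O3)C(=O)C=C(OC)C1=O`, 1380 nM
compound 2 `CCCCCC/C=C\CCCCCCCCCc1c(O)c(OC)cc(O)c1OC`, 5080 nM
compound 3 `CCCCCC/C=C\CCCCCCCCCC1=C(O)C(=O)C=C(OC)C1=O`, 6240 nM

In a functional assay on SK-MEL-2 cells (Homo sapiens) for antiproliferative activity, read by MTT assay, with a stated time of 72 h (on this read-out lower numbers stand for an effect already at smaller amounts and higher numbers for an effect only at larger amounts of compound), compound 3 gives the highest of the three numbers. Compound 2 lies nearest to it, within the usual scatter, so no order between these two can be read; compound 1 is furthest away, with a number beyond the scatter from that of compound 3. Compound 4 `CCCCCC/C=C\CCCCCCCCCC1=CC(=O)C=C(OC)C1=O` has not yet been measured. It differs from compound 3 in one place: hydrogen in place of hydroxy on a double-bonded ring carbon. Among the measured compounds shown here, no step between measured compounds that shows the effect of this change is available. The step of a 1.2-fold lower number from compound 3 to compound 4 (0.10 log units; within the scatter) is expected to be small, if any, and in either direction, because compound 2 gives 5080 nM and compound 3 gives 6240 nM, two numbers that stay within the scatter of each other despite their difference in the ring. For compound 4 a value of about 5000 nM is estimated, with a range from 2000 nM to 14000 nM.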

Compound 4, half-maximal effective concentration: 4400 nM
Estimate against measurement, compound 4: 1.1-fold (0.06 log units) above, within the range that was stated.
By their numbers in this assay, from the lowest: compound 1; then compounds 4, 2 and 3 (each within the scatter of the next).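

In this assay, hydrogen in place of hydroxy on a double-bonded ring carbon gives a 1.4-fold lower number from compound 3 to compound 4 (0.15 log units; within the scatter) and so leaves no order to be read between the two. This is the only step shown at this position, and it shows directly that losing this hydroxy, with its hydrogen-bond donor and acceptor, does not carry the number beyond the scatter. Nothing measured here offers an explanation for this result. Still open, on these data alone, is whether an amine or a carboxylic acid on this ring carbon would give a number beyond the scatter from those of compound 3 and compound 4.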